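This account rests on a few compounds, and the source may have more. Where it says the series, first, only, none or still open, it means among the compounds named here.

Compound 1, `Cc1cn(C2CC(N=[N+]=[N-])C(COC(=O)NCCCO)O2)c(=O)[nH]c1=O`, and compound 2, `Cc1cn(C2CC(N=[N+]=[N-])C(COC(=O)NCCCC(=O)O)O2)c(=O)[nH]c1=O`, share one core and differ in a single group. The change is carboxy in place of hydroxy on a saturated chain carbon, three bonds along the chain from an amide-type nitrogen. In a physicochemical assay for lipophilicity (on this read-out lower numbers stand for lower lipophilicity and higher numbers for higher lipophilicity), compound 1 gives -1.24, while compound 2 gives -0.81, so the step is a number 0.43 log units higher from compound 1 to compound 2 (beyond the scatter).

Compound 3, `Cc1cn(C2CC(N=[N+]=[N-])C(COC(=O)OCCCO)O2)c(=O)[nH]c1=O`, is the counterpart of compound 1 on a second core; the two cores differ by 3-hydroxypropoxy in place of (3-hydroxypropyl)amino on a carbonyl carbon. In this assay compound 3 gives -0.98, a step of a number 0.26 log units higher from compound 1 to compound 3 (within the scatter) and, against compound 2, a number 0.17 log units lower from compound 2 to compound 3 (within the scatter).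

Compound 4, `Cc1cn(C2CC(N=[N+]=[N-])C(COC(=O)OCCCC(=O)O)O2)c(=O)[nH]c1=O`, has not yet been measured. Against compound 3 it carries the change (carboxy in place of hydroxy on a saturated chain carbon, three bonds along the chain from an oxygen next to a carbonyl group). This is the same kind of change as that from compound 1 to compound 2, though not the same: there the carboxy sat three bonds along the chain from an amide-type nitrogen, here it sits three bonds along the chain from an oxygen next to a carbonyl group.

On that ground the step from compound 3 to compound 4 in this assay is expected to be about a number 0.43 log units higher from compound 3 to compound 4 (beyond the scatter), resting on the step of a number 0.43 log units higher from compound 1 to compound 2 (beyond the scatter). The estimate for compound 4 is therefore -0.55, between -0.9 and -0.2.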

Compound 4, partition coefficient: -0.55
For compound 4 middle estimate and measured number coincide at the digits printed; low and high end bracket the measured number.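

Carrying the change from hydroxy to carboxy onto the second core in this assay gives a number 0.43 log units higher from compound 3 to compound 4 (beyond the scatter) on that core, and the same change gave a number 0.43 log units higher from compound 1 to compound 2 (beyond the scatter) on the core of compound 1, so across these two cores the step has the same printed size even though its place differs, three bonds along the chain from an oxygen next to a carbonyl group rather than from an amide-type nitrogen. The comparison between the cores with carboxy on both sides gives a number 0.26 log units higher from compound 2 to compound 4 (within the scatter) and the comparison that takes in both changes gives a number 0.69 log units higher from compound 1 to compound 4 (beyond the scatter) as its largest step. This shows transfer for one change between two cores only, so it establishes no general rule, and nothing available accounts for the agreement of the two steps.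

The compounds shown leave open whether the same step would appear with a longer chain between the core and the carboxylic acid. They also leave open what an amine at the chain end would do on either core.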